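Shortening the Long Chain on a Sulfonamide Core

This account rests on a few compounds, and the source may have more. Where it says the series, first, only, none or still open, it means among the compounds named here.

Measured compounds:
compound 1, `CCc1ccccc1NS(=O)(=O)c1ccc(N2CCNC2=O)cc1` — 180 nM
compound 2, `CCCCCCCc1ccc(NS(=O)(=O)c2ccc(N3CCNC3=O)cc2)cc1` — > 1000 nM
compound 3, `COc1ccc(NS(=O)(=O)c2ccc(N3CCNC3=O)cc2)cc1OC` — 340 nM

The three compounds share one core and differ only in the groups on the ring that carries the sulfonamide nitrogen. They were tested in a functional assay on M21 cells (Homo sapiens) for antiproliferative activity, read by sulforhodamine B assay, with a stated time of 48 h; on this read-out lower numbers stand for stronger inhibition and higher numbers for weaker inhibition. Compound 1, with an ethyl group, gives 180 nM. Compound 3, with two methoxy groups, gives 340 nM. Going by the values given here, compound 2, with a heptyl chain, gives only > 1000 nM, which is a limit of this assay and not a number; it is the one value sitting at the limit of > 1000 nM in this assay, at which 1 of the 3 values shown sits. So compound 2 stands apart from the other two, which both give measured numbers.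

Compound 4, `CCCCCc1ccc(NS(=O)(=O)c2ccc(N3CCNC3=O)cc2)cc1`, has not been measured. It differs from compound 2 by hydrogen in place of ethyl on a saturated chain carbon, five bonds along the chain from an aromatic carbon. Among the compounds with values here, because compound 2 gives only a limit, no measured step shows how this chain length matters, and the size of the change cannot be read from the data. The step from compound 2 to compound 4 is expected to be an at least 1.2-fold lower number from compound 2 to compound 4 (0.09 log units; that floor lies within the scatter), toward stronger inhibition, since the shorter-substituted compound 1 and compound 3 both give numbers while compound 2 does not. Compound 4 is estimated at 800 nM, with a range from 250 nM to 3000 nM.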

Compound 4, half-maximal inhibitory concentration: 870 nM
Estimate against measurement, compound 4: 1.1-fold (0.04 log units) below; low and high end bracket the measured number.
By their numbers in this assay, from the lowest: compounds 1 and 3 (each within the scatter of the next); then compound 4. At a limit, above all of these: compound 2.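

Compound 4 gives the series its first actual number for a long straight chain on this ring: in this assay, compound 4 gives 870 nM. Going by these compounds alone, its partner in the comparison, compound 2, gives > 1000 nM, which is a limit of the assay and not a number, and it is the only such value in the set: the limit of > 1000 nM in this assay, at which 1 of the 4 values shown sits. The step therefore reads an at least 1.1-fold lower number from compound 2 to compound 4 (0.06 log units; that floor lies within the scatter), so hydrogen in place of ethyl on this saturated chain carbon shows no change that can be told apart from ordinary repeat variation, although the true gap could be larger, as only its floor is known.

Going by these compounds, how far the number would move with a still shorter chain, such as propyl or methyl on the same ring, remains open, as does the effect of a chain carrying an amine or a carboxylic acid. On these data alone, the true value of compound 2 also remains unknown, so the data cannot yet say whether chain length matters at this position or how steeply the activity depends on it.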